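The compounds below may be only part of what the source reports. "The series", "measured", "known", "first", "only" and "open" are said of these compounds alone.

Measured compounds:
compound 1 `Cc1ccc(NC(=O)Nc2nnc(Sc3ncnc4scc(-c5ccncc5)c34)s2)cc1` — 2100 nM
compound 2 `O=C(Nc1ccc(Cl)cc1)Nc1nnc(Sc2ncnc3scc(-c4ccncc4)c23)s1` — 7700 nM

In a functional assay on PC-3 cells (Homo sapiens) for antiproliferative activity, read by MTT assay, with a stated time of 48 h (a higher number here means a weaker inhibitor, a lower number a stronger inhibitor), compound 1 gives the lowest of the two numbers; compound 2 sits a 3.7-fold higher number from compound 1 to compound 2 (0.56 log units; beyond the scatter) away from it. Compound 3 `O=C(Nc1cccc(F)c1)Nc1nnc(Sc2ncnc3scc(-c4ccncc4)c23)s1` is the next compound. It differs from compound 1 by 3-fluorophenyl in place of 4-methylphenyl on an amide-type nitrogen. Among the measured compounds shown here, the only measured step that bears on it is a 3.7-fold higher number from compound 1 to compound 2 (0.56 log units; beyond the scatter), where a halogen took the place of the methyl and the number rose. A similar, modest rise is therefore expected here, though the fluorine stands at another position. Compound 3 is estimated at 5000 nM (range 2000 nM to 13000 nM), an expected step of a 2.4-fold higher number from compound 1 to compound 3 (0.38 log units; beyond the scatter).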

Compound 3, half-maximal inhibitory concentration: 6600 nM
The estimate for compound 3 lay 1.3-fold (0.12 log units) below the measured number; the range from low to high includes it.
By their numbers in this assay, from the lowest: compound 1; then compounds 3 and 2 (each within the scatter of the next).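

this assay shows a 3.1-fold higher number from compound 1 to compound 3 (0.50 log units; beyond the scatter) when 3-fluorophenyl replaces 4-methylphenyl, and a 1.2-fold lower number from compound 2 to compound 3 (0.07 log units; within the scatter) when it replaces 4-chlorophenyl. The two halogen-bearing phenyl groups thus read alike, and the 4-methylphenyl group of compound 1 alone keeps the lowest number of the three, so the rise is not confined to the 4-chlorophenyl group. No evidence at hand accounts for this.

Halogen and placement change together in compound 3, so their separate contributions stay open. Also open, from the compounds shown here alone, is whether a methoxy or dimethylamino group on the phenyl ring would read like compound 1 or like compound 2.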